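Removing a nitrile from compound 1: what to expect

The source may hold more compounds than are shown below. What is called first, only, known or untested is meant among the compounds shown, and "the series" means these compounds.

Measured compounds:
- compound 1, `COc1ccc2c(c1)c(-c1cc(C(F)(F)F)c(C#N)c(-c3cn(S(=O)(=O)c4ccc(C)cc4)c4ccc(OC)cc34)n1)cn2S(=O)(=O)c1ccc(C)cc1`: 25.2%
- compound 2, `COc1ccc2c(-c3cc(C(F)(F)F)c(C#N)c(-c4cn(S(=O)(=O)c5ccc(C)cc5)c5cc(OC)ccc45)n3)cn(S(=O)(=O)c3ccc(C)cc3)c2c1`: 13.3%
- compound 3, `Cc1ccc(S(=O)(=O)n2cc(-c3cc(C(F)(F)F)cc(-c4cn(S(=O)(=O)c5ccc(C)cc5)c5ccccc45)n3)c3ccccc32)cc1`: 27.6%

All three compounds were tested in a functional assay on A549 cells (Homo sapiens) for inhibition, tested at 10 uM; a higher number here means a stronger effect of the compound at the concentration tested, a lower number a weaker effect. Compound 1 sits second highest of the three numbers. Its nearest neighbour is compound 3, whose value lies within the scatter of compound 1, so the two cannot be told apart; compound 2 lies further off, beyond the scatter, and its value is the lower one. No two of these measured compounds differ in only one place, so no single step can be read off from them.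

Compound 4, `COc1ccc2c(c1)c(-c1cc(C(F)(F)F)cc(-c3cn(S(=O)(=O)c4ccc(C)cc4)c4ccc(OC)cc34)n1)cn2S(=O)(=O)c1ccc(C)cc1`, has not been measured. It differs from compound 1 in this way: hydrogen in place of cyano on an aromatic carbon. Compound 3 also carries a hydrogen at that place, yet it differs from compound 1 elsewhere as well, so it gives only a loose hint. Since compound 3 shows 27.6%, close to compound 1, no step beyond the scatter is expected in this assay; the expected step is a number 0.2 percentage points lower from compound 1 to compound 4 (within the scatter). Compound 4 is therefore estimated at 25%, with a range from 10% to 40%.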

Compound 4, a percentage reported as inhibition, at one concentration (the size of the read-out at that concentration, not a potency): 22.2%
For compound 4 the middle estimate is 2.8 percentage points above the measured one; measured number inside the range.
By their numbers in this assay, from the lowest: compounds 2, 4, 1 and 3 (each within the scatter of the next, the first and the last beyond it).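

In this assay, replacing the nitrile with hydrogen gives a number 3 percentage points lower from compound 1 to compound 4 (within the scatter). Within the data shown here, this is the first comparison here in which only one place changes, and it shows that, on this aromatic carbon ortho to a trifluoromethyl group, the nitrile can be lost with no change that can be told from the scatter at the single concentration tested. No independent data here explain this result.

The compounds shown leave open whether a different group at this same carbon, such as an amine or a carboxylic acid, would shift the number beyond the scatter. They also leave open whether removing the nitrile would give a similar step with the methoxy groups placed as in compound 2.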